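A furan-to-thiophene swap at the assay limit

This account rests on a few compounds, and the source may have more. Where it says the series, first, only, none or still open, it means among the compounds named here.

Of the compounds shown here, two have been measured so far in a functional assay on K562 cells (Homo sapiens), read by MTT assay, with a stated time of 72 h; a lower number here means a stronger inhibitor, a higher number a weaker inhibitor. Compound 1 `CNc1ncnc2c1c(-c1ccoc1)cn2[C@@H]1O[C@H](CO)[C@@H](O)[C@H]1O` gives > 20000 nM, which is a limit of the assay and not a number. Compound 2 `Nc1nc2c(c(-c3ccco3)cn2[C@@H]2O[C@H](CO)[C@@H](O)[C@H]2O)c(=O)[nH]1` gives > 20000 nM, which is also a limit. Compound 2 therefore has no exact value of its own, and the only other result offers no exact value to compare it with: the limit of > 20000 nM in this assay, at which 2 of the 2 values shown sit.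

The next compound, compound 3 `Nc1nc2c(c(-c3cccs3)cn2[C@@H]2O[C@H](CO)[C@@H](O)[C@H]2O)c(=O)[nH]1`, keeps the structure of compound 2 except in one place, with thiophen-2-yl in place of furan-2-yl on an aromatic carbon. Each group is a five-membered aromatic ring with 1 hetero atom, so the change amounts to sulfur replacing oxygen in that ring. For the measured compounds named here, no measured pair shows what such a swap does here. The expectation therefore rests on compound 2 alone, with its limit of > 20000 nM. The expected step is a number no higher from compound 2 to compound 3 (the limit leaves the size open), which means no change beyond the scatter in this assay. For compound 3 the estimated value is 20000 nM, with an expected range from 6000 nM to 40000 nM.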

Compound 3, half-maximal inhibitory concentration: 16800 nM
Estimate against measurement, compound 3: 1.2-fold (0.08 log units) above; the range from low to high includes it.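

With thiophen-2-yl on this aromatic carbon, compound 3 gives 16800 nM in this assay, the first exact number among the compounds shown, so a group at this position can bring the reading inside the measurable range. Compound 2 gives > 20000 nM, which is a limit and not a number. Going by these compounds, the exchange of furan-2-yl for thiophen-2-yl can therefore be read only as an at least 1.1-fold lower number from compound 2 to compound 3 (0.07 log units; that floor lies within the scatter), and the true size of the change remains unknown.

The series still offers little to compare, as most of its results sit at one ceiling: the limit of > 20000 nM in this assay, at which 2 of the 3 values shown sit. On these data alone, it remains open whether another group on this carbon, such as a phenyl ring or a simple amine, would give a lower number than compound 3, and whether thiophen-2-yl would give an exact value on the core of compound 1.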